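Replacing the Pyrimidin-2-yl Group: Estimating Compound 3

A few compounds are considered here, and "the series" means these few. Any claim that something is new, unique, unknown or untested is made for them only; others in the source may bear on it.

Compound 1 `S=C(Nc1ccccc1)N1CCN(c2ncccn2)CC1`: >= 200000 nM
Compound 2 `S=C(NCc1ccccc1)N1CCN(c2ncccn2)CC1`: 50900 nM

In a toxicity assay on RAW264.7 cells (Mus musculus) for cytotoxicity, read by MTT assay, with a stated time of 24 h (a higher number here means that more compound is tolerated, a lower number that less compound is tolerated), compound 1 gives only a limit, >= 200000 nM, as shown by the limit of >= 200000 nM in this assay, at which 1 of the 2 values shown sits. Compound 2 is measured at 50900 nM in this assay, and the step of an at least 3.9-fold lower number from compound 1 to compound 2 (0.59 log units; beyond the scatter) concerns the other nitrogen. Going by the values given here, compound 3 `S=C(Nc1ccccc1)N1CCN(c2ccccc2Cl)CC1` differs from compound 1 by 2-chlorophenyl in place of pyrimidin-2-yl on an amine nitrogen in a ring; no measured step touches this position. With no bearing evidence, compound 3 is expected to sit near compound 1, a step of an at least 1.3-fold lower number from compound 1 to compound 3 (0.12 log units; that floor lies within the scatter) that may fall within the scatter, giving an estimated 150000 nM, ranging from 40000 nM to 400000 nM.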

Compound 3, half-maximal cytotoxic concentration: 30500 nM
Compound 3: middle estimate off by 4.9-fold (0.69 log units), on the high side; the measured number lies below the stated range.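

In this assay the position on the amine nitrogen in a ring proves to matter, with an at least 6.5-fold lower number from compound 1 to compound 3 (0.81 log units; beyond the scatter) following when 2-chlorophenyl replaces pyrimidin-2-yl. A change at this end of the molecule, and not only on the other nitrogen, therefore moves the number beyond the scatter. Going by these compounds, the full size of this step remains unknown because compound 1 stands at a limit: the limit of >= 200000 nM in this assay, at which 1 of the 3 values shown sits.

On these data alone, what a plain phenyl or a pyridin-2-yl group would give on this nitrogen remains open. The role of the chlorine thus cannot be separated from that of the two ring nitrogens that leave.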